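From amino to acetamido on the shared core

The compounds below may be only part of what the source reports. "The series", "measured", "known", "first", "only" and "open" are said of these compounds alone.

Values measured in an ADME assay on MDBK cells (Bos taurus) for cytotoxicity, read by MTT assay, with a stated time of 96 h; on this read-out higher numbers stand for lower toxicity in this test and lower numbers for higher toxicity in this test:
Compound 1 `O=[N+]([O-])c1ccc(-c2nc3cc(Cl)c(Cl)cc3[nH]2)cc1`: 56000 nM
Compound 2 `O=[N+]([O-])c1ccc(-c2nc3cc(C(F)(F)F)ccc3n2C2CCCCC2)cc1`: 68000 nM
Compound 3 `Nc1ccc(-c2nc3cc(Cl)c(Cl)cc3[nH]2)cc1`: 7500 nM

In this assay, compound 3 holds the lowest number of the three at 7500 nM. Compound 4 `CC(=O)Nc1ccc(-c2nc3cc(Cl)c(Cl)cc3[nH]2)cc1` is compound 3 with acetyl in place of hydrogen on a nitrogen on an aromatic ring, a change from amino to acetamido: acetyl in place of hydrogen on a nitrogen on an aromatic ring.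

For the measured compounds named here, only one measured step bears on this change: a 7.5-fold lower number from compound 1 to compound 3 (0.87 log units; beyond the scatter), with amino in place of nitro on an aromatic carbon. Going by the values given here, it shows that a change at this group can move the number beyond the scatter, but no measured compound carries the acetamido group. A modest rise is therefore expected, on the reasoning that compound 3 sits low at 7500 nM and that with nitro in place of that amino group compound 1 stands higher at 56000 nM. The expected step is a 2.0-fold higher number from compound 3 to compound 4 (0.30 log units; within the scatter), and it remains uncertain. For compound 4 the estimated value is 15000 nM, with an expected range from 5000 nM to 60000 nM.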

Compound 4, half-maximal cytotoxic concentration: 58000 nM
For compound 4 the middle estimate is 3.9-fold (0.59 log units) below the measured one; low and high end bracket the measured number.
By their numbers in this assay, from the lowest: compound 3; then compounds 1, 4 and 2 (each within the scatter of the next).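

The acetyl group on the nitrogen on an aromatic ring takes the number well away from the low value of the free amine in this assay (a 7.7-fold higher number from compound 3 to compound 4 (0.89 log units; beyond the scatter)). Acetamido and nitro on that aromatic carbon then stand within the scatter of each other (a 1.0-fold higher number from compound 1 to compound 4 (0.02 log units; within the scatter)), so on the shared core only the free amino group of compound 3 sets itself apart among these three groups. Nothing available explains this difference between the amine and its acetylated form.

The compounds shown leave open how a propionyl group, a single methyl or a methanesulfonyl group on that same nitrogen would stand against the free amine. They also leave open whether an amino or acetamido group would give the same step on the core of compound 2.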